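Replacing the Oxolanyl Ether of Compound 1 with Methoxy

The source may report more compounds than this note shows. Statements on the series, on what has been measured and on what is new or still open speak of the compounds shown alone.

Compound 1 `O=C(N/N=C/c1ccc(O)c(Br)c1)Nc1cc2c(Nc3ccc(F)c(Cl)c3)ncnc2cc1O[C@H]1CCOC1`: 5230 nM
Compound 2 `O=C(N/N=C/c1cc(Br)c(O)c(Br)c1)Nc1cc2c(Nc3ccc(F)c(Cl)c3)ncnc2cc1O[C@H]1CCOC1`: 6160 nM
Compound 3 `O=C(N/N=C/c1ccc(O)cc1)Nc1cc2c(Nc3ccc(F)c(Cl)c3)ncnc2cc1O[C@H]1CCOC1`: 4890 nM

Three compounds on a shared core were tested in a functional assay on PC-3 cells (Homo sapiens) for cytotoxicity, read by MTT assay, with a stated time of 72 h; a lower number here means a stronger inhibitor, a higher number a weaker inhibitor. Compound 1 gives 5230 nM, the second highest of the three numbers. In this assay compound 3 gives 4890 nM and compound 2 gives 6160 nM. The steps of a 1.2-fold higher number from compound 1 to compound 2 (0.07 log units; within the scatter), a 1.1-fold lower number from compound 1 to compound 3 (0.03 log units; within the scatter) and a 1.3-fold lower number from compound 2 to compound 3 (0.10 log units; within the scatter) all lie within the scatter, so the three numbers cannot be ordered.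

Compound 4 `COc1cc2ncnc(Nc3ccc(F)c(Cl)c3)c2cc1NC(=O)N/N=C/c1ccc(O)c(Br)c1` differs from compound 1 by methyl in place of oxolan-3-yl on an oxygen on an aromatic ring. Within the data shown here, every measured step concerns bromo on the 4-hydroxyphenyl end; none touches this oxygen, so no measured step bears on the change, and the expectation rests on compound 1 alone. Compound 4 is expected to give 5200 nM (range 2000 nM to 13500 nM), an estimated step of a 1.0-fold lower number from compound 1 to compound 4 (0.00 log units; within the scatter) that stays within the scatter.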

Compound 4, half-maximal inhibitory concentration: 15300 nM
Beside the measured number, compound 4's estimate is 2.9-fold (0.47 log units) below it; the whole stated range lies below it.
By their numbers in this assay, from the lowest: compounds 3, 1 and 2 (each within the scatter of the next); then compound 4.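

In this assay, methyl in place of oxolan-3-yl on the oxygen on the aromatic ring gives a 2.9-fold higher number from compound 1 to compound 4 (0.47 log units; beyond the scatter). This oxygen substituent therefore moves the number beyond the scatter, which none of the bromo changes on the 4-hydroxyphenyl end did, and methoxy does not stand in for (oxolan-3-yl)oxy here. Nothing shown accounts for the step.

Open, going by these compounds, is whether the ring itself matters, which a methoxyethyl chain or a morpholine-bearing chain on the same oxygen would test. Also open, on these data alone, is whether the step recurs with the dibromo or bromo-free 4-hydroxyphenyl ends of compound 2 and compound 3.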